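Swapping methylamino for methoxy on a weakly active nucleoside

The compounds below may be only part of what the source reports. "The series", "measured", "known", "first", "only" and "open" are said of these compounds alone.

Compound 3 `CNc1ncnc2c1c(I)cn2[C@@H]1O[C@H](CO)[C@@H](O)[C@H]1O` was tested in an ADME assay on BJ cells (Homo sapiens), read by MTT assay, with a stated time of 72 h (on this read-out higher numbers stand for weaker inhibition and lower numbers for stronger inhibition), and gives only a limit, > 100000 nM, so no number is known for it. Compound 1 `Cc1ncnc2c1c(I)cn2[C@@H]1O[C@H](CO)[C@@H](O)[C@H]1O` likewise gives only a limit in this assay, > 100000 nM. Going by the values given here, compound 2 `COc1ncnc2c1c(-c1cccs1)cn2[C@@H]1O[C@H](CO)[C@@H](O)[C@H]1O` is the one measured value in the set and gives 62800 nM in this assay. Among the compounds with values here, the single step between measured compounds, a step that the two limits leave unreadable from compound 1 to compound 3, cannot be read in size because the limit of > 100000 nM in this assay, at which 2 of the 3 values shown sit, applies to both of its ends.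

Compound 4 `COc1ncnc2c1c(I)cn2[C@@H]1O[C@H](CO)[C@@H](O)[C@H]1O` is the compound not yet measured. It differs from compound 3 in one place: methoxy in place of methylamino on an aromatic carbon. Within the data shown here, no measured step bears directly on this change. Compound 3 stands at the limit and compound 2, which also carries a methoxy, sits not far from it, so compound 4 is expected to remain weak, with a step of a number no higher from compound 3 to compound 4 (the limit leaves the size open) that is estimated to stay within the scatter. The estimate for compound 4 in this assay is 100000 nM, within a range from 40000 nM to 300000 nM.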

Compound 4, half-maximal inhibitory concentration: 91000 nM
The estimate for compound 4 lay 1.1-fold (0.04 log units) above the measured number; the measured number falls inside the stated range.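

With iodo kept in place, in this assay the methoxy compound gives a number where the methylamino and methyl compounds give only limits, and the change appears as an at least 1.0-fold lower number from compound 3 to compound 4 (0.04 log units; that floor lies within the scatter) and as an at least 1.0-fold lower number from compound 1 to compound 4 (0.04 log units; that floor lies within the scatter). Going by these compounds, both steps are only floors, and their true size stays unknown, because one end of each sits at a limit: the limit of > 100000 nM in this assay, at which 2 of the 4 values shown sit. With methoxy kept in place, swapping thiophen-2-yl for iodo gives a 1.4-fold higher number from compound 2 to compound 4 (0.16 log units; within the scatter), so these two groups cannot be told apart here.

On these data alone, the real distance between methoxy and methylamino stays open, as compound 3 carries only a limit. The compounds shown also do not tell whether an ethoxy group or a plain amino group on this aromatic carbon would move the number beyond the scatter.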